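Ethyl for Methyl on the Ring Amine of Compound 2

The compounds below may be only part of what the source reports. "The series", "measured", "known", "first", "only" and "open" are said of these compounds alone.

Compound 1, `CC(O)(C#Cc1ccc(N2CC3CC2CN3)c(Nc2ncnc3[nH]ccc23)c1)c1nccs1`: 200 nM
Compound 2, `CN1CCN(c2ccc(C#CC(C)(O)c3nccs3)cc2Nc2ncnc3[nH]ccc23)CC1`: 78.3 nM

In an assay for inhibition of mitogen-activated protein kinase kinase kinase 14 (Homo sapiens), read by luminescence and ADP-Glo, with a stated time of 120 min, in the presence of a further agent that is not named here (on this read-out lower numbers stand for stronger inhibition and higher numbers for weaker inhibition), compound 2 holds the lower of the two numbers measured, and the other measured compound lies a step above it, a 2.6-fold lower number from compound 1 to compound 2 (0.41 log units; beyond the scatter). Compound 3, `CCN1CCN(c2ccc(C#CC(C)(O)c3nccs3)cc2Nc2ncnc3[nH]ccc23)CC1`, differs from compound 2 by methyl in place of hydrogen on a saturated chain carbon bound to an amine nitrogen in a ring. Among the compounds with values here, no measured step bears directly on this change: the single measured step exchanges one ring group for another on an aromatic carbon and gives no guide to methyl against ethyl. Compound 3 is therefore expected to show no step beyond the scatter, a 1.0-fold lower number from compound 2 to compound 3 (0.02 log units; within the scatter). The estimated value of compound 3 is 75 nM, ranging from 30 nM to 180 nM.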

Compound 3, half-maximal inhibitory concentration: 34.5 nM
Compound 3: the middle estimate sits 2.2-fold (0.34 log units) above what was measured; the measured number falls inside the stated range.
By their numbers in this assay, from the lowest: compound 3; then compound 2; then compound 1.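

In this assay the change from 4-methylpiperazin-1-yl to 4-ethylpiperazin-1-yl gives a 2.3-fold lower number from compound 2 to compound 3 (0.36 log units; beyond the scatter) on this ring amine, so this position responds to a single added carbon, which the earlier ring exchange could not show. Set against the ring group of compound 1, the ethyl group gives a 5.8-fold lower number from compound 1 to compound 3 (0.76 log units; beyond the scatter) overall. Nothing measured here offers a reason for either step.

On these data alone, whether a longer chain such as propyl, or a hydroxyethyl group, would carry this direction further stays open. One pair cannot say how far the trend runs.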